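Aryl sulfonamide series: trifluoromethyl analogue of compound 2

The compounds below may be only part of what the source reports. "The series", "measured", "known", "first", "only" and "open" are said of these compounds alone.

Measured so far in a functional assay on A-375 cells (Homo sapiens) for cytotoxicity, read by MTT assay; a higher number here means a weaker inhibitor, a lower number a stronger inhibitor:
Compound 1, `O=S(=O)(NCCCNc1nccc(-c2c(-c3cccc(F)c3)nc3sccn23)n1)c1ccc(Br)cc1`: 7040 nM
Compound 2, `Cc1ccc(S(=O)(=O)NCCCNc2nccc(-c3c(-c4cccc(F)c4)nc4sccn34)n2)cc1`: 8380 nM
Compound 3, `O=C(NCCCNc1nccc(-c2c(-c3cccc(F)c3)nc3sccn23)n1)c1ccc(F)cc1`: 14900 nM

Compound 2 sits among three closely grouped numbers. Its nearest neighbour is compound 1, with a 1.2-fold higher number from compound 1 to compound 2 (0.08 log units; within the scatter), and the gap to compound 3, a 1.8-fold higher number from compound 2 to compound 3 (0.25 log units; within the scatter), also lies within the scatter. For the measured compounds named here, the only step that stands beyond the scatter is a 2.1-fold higher number from compound 1 to compound 3 (0.33 log units; beyond the scatter), and it is modest.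

The next compound, compound 4, `O=S(=O)(NCCCNc1nccc(-c2c(-c3cccc(F)c3)nc3sccn23)n1)c1ccc(C(F)(F)F)cc1`, differs from compound 2 in one place: trifluoromethyl in place of methyl on an aromatic carbon. Going by the values given here, the one measured step that touches the same position on the same aromatic ring is a 1.2-fold higher number from compound 1 to compound 2 (0.08 log units; within the scatter), bromo exchanged for methyl, which stayed within the scatter. Nothing in the measured set separates a trifluoromethyl from a methyl or a bromo at that carbon, so the expectation rests on the bromo-to-methyl step alone, and the replacement of one group by another on that ring is expected to move the number little, in no set direction, with a step of a 1.1-fold lower number from compound 2 to compound 4 (0.05 log units; within the scatter) not beyond the scatter.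

Compound 4 is therefore estimated at 7500 nM in this assay, within 3500 nM to 16000 nM.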

Compound 4, half-maximal inhibitory concentration: 4090 nM
For compound 4 the middle estimate is 1.8-fold (0.26 log units) above the measured one; the measured number falls inside the stated range.
By their numbers in this assay, from the lowest: compounds 4, 1, 2 and 3 (each within the scatter of the next, the first and the last beyond it).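

For the compounds shown here, at this aromatic carbon in this assay, trifluoromethyl in place of methyl gives the only step at this position that passes the scatter, though a modest one (a 2.0-fold lower number from compound 2 to compound 4 (0.31 log units; beyond the scatter)), so the position is not wholly indifferent to the group it carries. Bromo remains inseparable from both other groups, since trifluoromethyl in place of bromo stays within the scatter (a 1.7-fold lower number from compound 1 to compound 4 (0.24 log units; within the scatter)), as does methyl in place of bromo (a 1.2-fold higher number from compound 1 to compound 2 (0.08 log units; within the scatter)), and the three groups therefore form no clear order: only the methyl and trifluoromethyl compounds stand apart. No measurement shown bears on what lies behind the separation of these two groups.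

From the compounds shown here alone, whether the separation extends to other groups at this carbon, such as a methoxy, a nitrile or an amine, stays open, and one modest step cannot show whether the position offers more than this small range. A fluoro on the sulfonyl-bearing ring would allow the exchange of sulfonyl for carbonyl to be read in one place, and a longer chain would test the linker, which is the same in all the compounds shown.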